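A few compounds are considered here, and "the series" means these few. Any claim that something is new, unique, unknown or untested is made for them only; others in the source may bear on it.

Measured compounds:
- compound 1, `O=C(Nc1ccc2nc(NC(=O)C3CCCCC3)sc2c1)c1cccnc1Cl`: 0.075 ug/mL
- compound 2, `CC(C)COC(=O)Nc1ccc2nc(NC(=O)C3CCCCC3)sc2c1`: 0.72 ug/mL
- compound 3, `O=C(Nc1ccc2nc(NC(=O)C3CC3)sc2c1)c1c(Cl)cccc1Cl`: 0.013 ug/mL

All three were tested in a functional assay on WI-38 VA13 cells (Homo sapiens) for cytotoxicity; a higher number here means that more compound is needed for the effect, a lower number that less compound is needed. Compound 3 gives the lowest number of the three, with compound 1 as its nearest neighbour and compound 2 furthest away. The new compound 4, `O=C(Nc1nc2ccc(NC(=O)c3c(Cl)cccc3Cl)cc2s1)OCc1ccccc1`, is compound 3 with benzyloxy in place of cyclopropyl on a carbonyl carbon; cut one bond further out, cyclopropylcarbonyl becomes benzyloxycarbonyl.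

For the measured compounds named here, only one measured step bears on this change, and only loosely: a 9.6-fold higher number from compound 1 to compound 2 (0.98 log units; beyond the scatter). There, too, an oxygen-linked group (isobutoxy) replaced a carbon-linked group on a carbonyl carbon, and the number rose. The present change sits on the carbonyl carbon attached to the amide-type nitrogen and swaps a small three-membered ring for a larger group carrying a six-membered aromatic ring, so the earlier step is a guide in direction more than in size.

A higher number than compound 3 is therefore expected, with a step of about a 4.6-fold higher number from compound 3 to compound 4 (0.66 log units; beyond the scatter). For compound 4 the estimate is 0.06 ug/mL, likely between 0.015 ug/mL and 0.3 ug/mL.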

Compound 4, half-maximal effective concentration: 0.018 ug/mL
Compound 4: middle estimate off by 3.3-fold (0.52 log units), on the high side; the measured number falls inside the stated range.
By their numbers in this assay, from the lowest: compounds 3 and 4 (each within the scatter of the next); then compound 1; then compound 2.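

In this assay, benzyloxy in place of cyclopropyl on the carbonyl carbon attached to the amide-type nitrogen gives a 1.4-fold higher number from compound 3 to compound 4 (0.14 log units; within the scatter), so this place takes a much larger group, carrying an oxygen and a six-membered aromatic ring, with no change beyond the usual scatter. The clear rise seen when an oxygen-linked group entered at another carbonyl carbon, a 9.6-fold higher number from compound 1 to compound 2 (0.98 log units; beyond the scatter), is not repeated here. No measurement is available that offers a reason for this result.

On these data alone, the oxygen and the aromatic ring enter together, so their separate contributions remain unknown; a plain benzyl group, which keeps the ring without the oxygen, would begin to separate them. Also open, as far as these compounds go, is whether this place would equally accept an amine or a carboxylic acid on that ring.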